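Adding a 4-Bromophenyl Group to Compound 2

A few compounds are considered here, and "the series" means these few. Any claim that something is new, unique, unknown or untested is made for them only; others in the source may bear on it.

Of the compounds shown here, two have so far been tested in a functional assay on PC-12 cells (Rattus norvegicus) for cytotoxicity, read by MTT assay, with stated times of 3 h and 2 h, tested at 10 uM; on this read-out lower numbers stand for a weaker effect and higher numbers for a stronger effect at the one concentration tested. Compound 1 `COc1ccc(-c2cc3ccc(OCCCn4cc(CNC(=O)CCCCC5CCSS5)nn4)cc3oc2=O)cc1` gives 57.6% in this assay, and compound 2 `O=C(CCCCC1CCSS1)NCc1cn(CCCCOc2ccc3ccc(=O)oc3c2)nn1` gives 65.1%. Compound 2 holds the higher of the two numbers, yet the gap to compound 1 lies within the scatter of repeated measurements, so the two compounds cannot be separated on this read-out.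

Compound 3 `O=C(CCCCC1CCSS1)NCc1cn(CCCCOc2ccc3cc(-c4ccc(Br)cc4)c(=O)oc3c2)nn1` is the next compound in line. It differs from compound 2 in a single place: 4-bromophenyl in place of hydrogen on an aromatic carbon. For the measured compounds named here, no measured pair shows this exact change on its own, so the direction of the step is not fixed by the existing numbers. Compound 1 carries a different aryl group on a core that also differs from compound 2 in its linker; compound 1 gives 57.6%, and this offers only a loose hint of where an aryl-bearing analogue might land.

For compound 3 the step of a number 7.1 percentage points lower from compound 2 to compound 3 (within the scatter) is expected to be small, perhaps slightly downward, or none beyond the scatter. Compound 3 is therefore estimated at 58% in this assay, with a range from 42% to 74%.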

Compound 3, a percentage reported as activity, at one concentration (the size of the read-out at that concentration, not a potency): 42.6%
Estimate against measurement, compound 3: 15.4 percentage points above; measured number inside the range.
By their numbers in this assay, from the lowest: compound 3; then compounds 1 and 2 (each within the scatter of the next).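

In this assay, for the compounds shown here, putting 4-bromophenyl in place of hydrogen gives a number 22.5 percentage points lower from compound 2 to compound 3 (beyond the scatter), the first change at a single place that can be read. It shows that this aromatic carbon, two atoms from the ring oxygen, does not tolerate every substituent without consequence: here the added aromatic ring moves the read-out towards a weaker effect at the one concentration tested, by more than repeated measurements would scatter. Nothing in the available data speaks to the reason for this fall.

From the compounds shown here alone, it remains open whether the lower number goes with the bromine or with the phenyl ring itself, a question that an unsubstituted phenyl or a 4-chlorophenyl at the same carbon, on the otherwise unchanged structure of compound 2, would address. Also open, going by these compounds, is whether a much smaller group at this carbon, such as methyl, or a ring carrying an amine would shift the number in the same direction, since a single step at a single concentration fixes no trend for this position.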